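The source may hold more compounds than are shown below. What is called first, only, known or untested is meant among the compounds shown, and "the series" means these compounds.

Compound 1 `O=S(=O)(Nc1ccc2oc(-c3ccccc3)nc2c1)c1ccc(Cl)c(Cl)c1` is a sulfonamide that was tested in an ADME assay on HEK293 cells (Homo sapiens) for cytotoxicity, read by resazurin assay, with a stated time of 48 h (a higher number here means that more compound is tolerated, a lower number that less compound is tolerated), where compound 1 gives 71000 nM. Among the two results shown it holds the only actual number. Compound 2 `Cc1cccc(S(=O)(=O)Nc2ccc(-c3nc4ccccc4o3)cc2)c1` reaches only a limit of this assay, giving > 100000 nM, so its cytotoxic concentration is not pinned down; this is the limit of > 100000 nM in this assay, at which 1 of the 2 values shown sits.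

Compound 3 `O=S(=O)(Nc1ccc2oc(-c3ccccc3)nc2c1)c1cccc(O)c1` has not yet been tested. It differs from compound 1 in one place:

3-hydroxyphenyl in place of 3,4-dichlorophenyl on a sulfonyl sulfur

For the measured compounds named here, no measured pair of compounds shows what such a change does in this assay, so the expected step rests on compound 1 alone and on the fact that one of two results already sits at the limit. The step expected from this change, a 1.5-fold higher number from compound 1 to compound 3 (0.19 log units; within the scatter), points toward more compound being tolerated, though a result within the scatter would not be surprising. Compound 3 is therefore estimated at 110000 nM, with a range from 45000 nM to 250000 nM.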

Compound 3, half-maximal cytotoxic concentration: > 100000 nM
Compound 3: a limit, no number; the forecaster's own chance of this, stated with the estimate: 55%; the middle value is on the limit's open side.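

This is the only step shown on the sulfonyl sulfur, and in this assay it reads as an at least 1.4-fold higher number from compound 1 to compound 3 (0.14 log units; that floor lies within the scatter), so 3-hydroxyphenyl in place of 3,4-dichlorophenyl gives no sign of less compound being tolerated. Only the lowest possible size of this step is known, and because that floor lies within the scatter, the two compounds cannot be firmly separated, even though the true step could be much larger. The upper end of the assay now restricts what can be read from these compounds: the limit of > 100000 nM in this assay, at which 2 of the 3 values shown sit.

For the compounds shown here, the single swap removes both chlorines and adds a hydroxy group at once, so the part played by each remains open. The compounds shown also leave open how an amine, a carboxylic acid or an unsubstituted phenyl at this position would behave.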